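The compounds below may be only part of what the source reports. "The series", "measured", "known", "first", "only" and "open" are said of these compounds alone.

Measured compounds and their growth-inhibition values:

Compound 1 `O=C(/C=C/c1cccc(O)c1)c1cccc(-n2cc(-c3ccccc3)[nH]c2=O)c1` with 3180 nM
Compound 2 `COc1cc(/C=C/C(=O)c2cccc(-n3cc(-c4ccccc4)[nH]c3=O)c2)cc(OC)c1OC` with 1400 nM
Compound 3 `COc1ccc(-c2cn(-c3cccc(C(=O)/C=C/c4ccc(O)c(OC)c4)c3)c(=O)[nH]2)cc1` with 2630 nM

In a functional assay on SK-MEL-5 cells (Homo sapiens) for inhibition (a lower number here means a stronger inhibitor of growth, a higher number a weaker inhibitor of growth), compound 2 gives the lowest of the three numbers. Its value and that of compound 3 lie within the scatter of each other, so no order between them can be claimed; only compound 1 sits clearly higher than compound 2, beyond the scatter. Compound 4 `COc1cc(/C=C/C(=O)c2cccc(-n3cc(-c4cc(OC)c(OC)c(OC)c4)[nH]c3=O)c2)cc(OC)c1OC` has not yet been measured in this assay. It differs from compound 2 in one place: 3,4,5-trimethoxyphenyl in place of phenyl on an aromatic carbon. Within the data shown here, no measured pair in this set isolates that change, so its size is unknown here. The change duplicates on the second aryl group the same substitution pattern that compound 2 already carries on the other side, and the step from compound 1 to compound 2 shows that pattern going with a lower number there. The step is therefore expected to be small, in the direction of a lower number or none beyond the scatter, giving a 1.3-fold lower number from compound 2 to compound 4 (0.10 log units; within the scatter) as the estimate. Compound 4 is expected to give 1100 nM, with a range from 400 nM to 3500 nM.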

Compound 4, concentration for 50% growth inhibition: 2760 nM
The estimate for compound 4 lay 2.5-fold (0.40 log units) below the measured number, within the range that was stated.
By their numbers in this assay, from the lowest: compounds 2, 3, 4 and 1 (each within the scatter of the next, the first and the last beyond it).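

In this assay, among these compounds, replacing phenyl with 3,4,5-trimethoxyphenyl on the aromatic carbon of the five-membered ring gives a 2.0-fold higher number from compound 2 to compound 4 (0.29 log units; within the scatter), and this is the first direct reading of a change at this position. The larger aryl group is therefore tolerated here, with no difference from phenyl that can be told apart from the scatter, and the pair gives no sign that adding the three methoxy groups lowers the number. Nothing available explains this result.

On these data alone, it remains open whether a different group at this position, such as an aminophenyl, a carboxyphenyl or a small alkyl chain in place of the aryl ring, would move the number beyond the scatter. Among the compounds shown here, the single pair also cannot show whether the same change would give a similar step on a different side chain.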